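Sulfonyl aryl changes in the pyrimidinylaminomethyl benzamide series

The source may report more compounds than this note shows. Statements on the series, on what has been measured and on what is new or still open speak of the compounds shown alone.

Compound 1 `O=C(NCc1ccc(CNS(=O)(=O)c2ccc3c(c2)CCO3)cc1)c1ccc(CNc2ncccn2)cc1` gives 1000 nM in an assay on MDA-MB-231 cells for binding affinity to C-X-C chemokine receptor type 4 (Homo sapiens), read by microscopy, with stated times of 10 min and 30 min; on this read-out lower numbers stand for an effect already at smaller amounts and higher numbers for an effect only at larger amounts of compound. Compound 2 `O=C(NCc1ccc(CNS(=O)(=O)c2cccc(F)c2)cc1)c1ccc(CNc2ncccn2)cc1` gives 1000 nM in this assay, and the exchange of the bicyclic sulfonyl group for the fluorinated ring leaves the read-out unmoved: no change at the digits printed from compound 1 to compound 2 (within the scatter). Compound 3 `O=C(NCc1ccc(CNS(=O)(=O)c2ccc(F)cc2)cc1)c1ccc(CNc2ncccn2)cc1` reaches only a limit in this assay, reported as > 1000 nM. Going by the values given here, compound 3 is therefore the one member whose number is not resolved, as recorded in the limit of > 1000 nM in this assay, at which 1 of the 3 values shown sits. From the compounds shown here alone, the steps leading to it, a number no lower from compound 1 to compound 3 (the limit leaves the size open) and a number no lower from compound 2 to compound 3 (the limit leaves the size open), say only that the read-out did not fall; their size stays open.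

Compound 4 `Cc1ccccc1S(=O)(=O)NCc1ccc(CNC(=O)c2ccc(CNc3ncccn3)cc2)cc1` differs from compound 3 in the group on the sulfonyl sulfur: 2-methylphenyl in place of 4-fluorophenyl on a sulfonyl sulfur. Among the compounds with values here, the one measured step that touches the same place is the shift of the fluorine from 3-fluorophenyl to 4-fluorophenyl, and it gave no lower number. Nothing measured shows a methyl on that ring, so the size of the coming step cannot be read from the series. The working expectation is that compound 4 stays close to where compound 3 sits, near the upper edge of this assay. Compound 4 is estimated at 1200 nM, within 400 nM to 5000 nM, which is expected to mean a step that the limit leaves unreadable from compound 3 to compound 4.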

Compound 4, effective concentration (reported as EC, without a stated level of effect): 10 nM
Beside the measured number, compound 4's estimate is 120-fold (2.08 log units) above it; the measured number lies below the stated range.
By their numbers in this assay, from the lowest: compound 4; then compounds 1 and 2 (each within the scatter of the next).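

Up to compound 3, changes in the group on the sulfonyl sulfur had shown no readable fall in this assay, whereas this position now proves able to carry a large shift, with 2-methylphenyl giving a 100-fold lower number from compound 2 to compound 4 (2.00 log units; beyond the scatter) and, against the bicyclic group, a 100-fold lower number from compound 1 to compound 4 (2.00 log units; beyond the scatter). Against 4-fluorophenyl the change gives an at least 100-fold lower number from compound 3 to compound 4 (2.00 log units; beyond the scatter), although the leaving and entering groups match in heavy atoms, in their six-membered aromatic ring of carbon only, and in hydrogen-bond donors and acceptors, so these counts do not track the read-out here. The value of compound 3 is a limit and not a number: the limit of > 1000 nM in this assay, at which 1 of the 4 values shown sits.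

Still open, from the compounds shown here alone, is whether the shift belongs to the methyl itself or to where it sits on the ring, a question that a comparison of 2-methylphenyl with 4-methylphenyl and 2-fluorophenyl on the same sulfonyl sulfur would address. Also open, going by these compounds, is how much room the position allows beyond a methyl, for example with 2-ethylphenyl or 2-methoxyphenyl, and whether the shift holds outside this assay.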